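The source may report more compounds than this note shows. Statements on the series, on what has been measured and on what is new or still open speak of the compounds shown alone.

Measured in an ADME assay on microsomes from liver (Homo sapiens) for metabolic stability, with a stated time of 60 min, tested at 1 uM; on this read-out lower numbers stand for a less stable compound and higher numbers for a more stable compound:
Compound 1 `COc1cc(-c2cnn3cc(OC)c(-c4cc(C)no4)nc23)ccn1`: 31%
Compound 2 `COc1cc(-c2cnn3cc(OC)c(C4CCOC4)nc23)ccn1`: 29%

For the measured compounds named here, compound 2 cannot be told apart from compound 1, since the only measured step, a number 2 percentage points lower from compound 1 to compound 2 (within the scatter), lies within the scatter. Compound 3 `COc1cc(-c2cnn3cc(OC)c([C@@H]4COC(C)(C)C4)nc23)ccn1` differs from compound 2 on an aromatic carbon: a group of 7 heavy atoms (6 carbon, 1 oxygen; one five-membered non-aromatic ring with 1 hetero atom) in place of a group of 5 heavy atoms (4 carbon, 1 oxygen; one five-membered non-aromatic ring with 1 hetero atom), on an aromatic carbon. That measured step changed the group on the same carbon, but it swapped a different group, so it offers only loose guidance. No step beyond the scatter is therefore expected in this assay, and the estimated change is a number 3 percentage points higher from compound 2 to compound 3 (within the scatter). The expected value for compound 3 is 32%, within an estimated range of 15% to 55%.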

Compound 3, percent of the compound remaining: 13%
Compound 3: the middle estimate sits 19 percentage points above what was measured; the measured number lies below the stated range.
By their numbers in this assay, from the lowest: compound 3; then compounds 2 and 1 (each within the scatter of the next).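

In this assay, this position on an aromatic carbon now proves sensitive to the group it carries: where the earlier pair could not be told apart, there is a number 16 percentage points lower from compound 2 to compound 3 (beyond the scatter) once the extra heavy atoms, both carbon, are added to the five-membered non-aromatic ring. Against the aromatic 3-methyl-1,2-oxazol-5-yl group, the same ring gives a number 18 percentage points lower from compound 1 to compound 3 (beyond the scatter) on this read-out. Nothing available accounts for this loss. The compounds shown leave open whether a single methyl group on the oxolan-3-yl ring would already lower the number, and whether a hydroxyl group or an amine there would do the same.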